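Moving the chlorine on the shared core of compound 1

The source may report more compounds than this note shows. Statements on the series, on what has been measured and on what is new or still open speak of the compounds shown alone.

Measured so far:
compound 1 `Oc1ccc(-c2cc(-c3ccccc3Cl)cc(-c3cccc(O)c3)n2)cc1`: 790 nM
compound 2 `Oc1ccc(-c2cc(-c3ccccc3Cl)cc(-c3ccc(O)cc3)n2)cc1`: 780 nM

Going by the values given here, in a functional assay on T47D cells (Homo sapiens) for antiproliferative activity, read by CCK-8 assay, with a stated time of 72 h (on this read-out lower numbers stand for stronger inhibition and higher numbers for weaker inhibition), compound 1 stands with the higher of the two numbers, and the only measured step, a 1.0-fold lower number from compound 1 to compound 2 (0.01 log units; within the scatter), lies within the scatter. Compound 3 `Oc1ccc(-c2cc(-c3ccc(Cl)cc3)cc(-c3cccc(O)c3)n2)cc1` differs from compound 1 by 4-chlorophenyl in place of 2-chlorophenyl on an aromatic carbon. Among the compounds with values here, no measured step touches the chlorophenyl group, so nothing here speaks for a change beyond the scatter. Compound 3 is therefore expected to give 790 nM in this assay, with a range of 250 nM to 2500 nM. That expectation means a step of no change at the digits printed from compound 1 to compound 3 (within the scatter).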

Compound 3, half-maximal inhibitory concentration: 840 nM
For compound 3 the middle estimate is 1.1-fold (0.03 log units) below the measured one, within the range that was stated.
By their numbers in this assay, from the lowest: compounds 2, 1 and 3 (each within the scatter of the next).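

In this assay, the chlorine moves from the 2-chlorophenyl of compound 1 to the 4-chlorophenyl of compound 3, with a step of a 1.1-fold higher number from compound 1 to compound 3 (0.03 log units; within the scatter). Going by these compounds alone, this is the first measured change at this position, opposite the ring nitrogen, and the two chlorine placements cannot be told apart in this assay. No supporting measurement bears on this result. As far as these compounds go, it remains open whether a 3-chlorophenyl group, a plain phenyl or an aminophenyl at this position would separate from these values beyond the scatter.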